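The compounds below may be only part of what the source reports. "The series", "measured", "known", "first", "only" and "open" are said of these compounds alone.

Working notes on the series.

Three compounds have numbers in a functional assay on A549 cells (Homo sapiens) for inhibition, read by sulforhodamine B assay, with a stated time of 48 h; on this read-out higher numbers stand for weaker inhibition and lower numbers for stronger inhibition. Compound 1, `COc1ccc(C(O)(Cc2ccc(F)cc2)c2cccc3ccccc23)c(OC)c1OC`, gives 5940 nM and has the lowest number of the three. Compound 2, `COc1ccc(/C(=N/OC(C)=O)c2cccc3ccccc23)c(OC)c1OC`, gives 17200 nM and compound 3, `COc1cc(COC(c2ccc(OC)c(OC)c2OC)c2cccc3ccccc23)cc(OC)c1`, gives 17500 nM; both stand beyond the usual scatter from compound 1, so compound 1 is the strongest inhibitor among the measured compounds. Going by the values given here, no pair among the three differs in a single place, so no single-change step has been worked out for them, and the two weaker compounds differ from compound 1 in several respects at once.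

Compound 4, `C=CCC(O)(c1ccc(OC)c(OC)c1OC)c1cccc2ccccc12`, is not yet measured. It differs from compound 1 in one place: vinyl in place of 4-fluorophenyl on a saturated chain carbon, two bonds along the chain from two aromatic carbons and an oxygen on a saturated carbon. The tertiary alcohol and the rest of the shared core are retained.

Among the compounds with values here, with no measured step of this kind to lean on, the expectation rests on compound 1 alone, which gives 5940 nM in this assay. Trading the 4-fluorophenyl for the smaller vinyl is expected to cost some inhibition, so the step from compound 1 to compound 4 is estimated as a 1.9-fold higher number from compound 1 to compound 4 (0.27 log units; within the scatter), a modest rise toward weaker inhibition, near the edge of the scatter. For compound 4 the estimate in this assay is 11000 nM, with a range from 3500 nM to 35000 nM.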

Compound 4, half-maximal inhibitory concentration: 10700 nM
The estimate for compound 4 lay 1.0-fold (0.01 log units) above the measured number; the range from low to high includes it.
By their numbers in this assay, from the lowest: compounds 1, 4, 2 and 3 (each within the scatter of the next, the first and the last beyond it).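

In this assay, going by these compounds alone, the step of a 1.8-fold higher number from compound 1 to compound 4 (0.26 log units; within the scatter) is the first single-change comparison, with vinyl in place of 4-fluorophenyl on a saturated chain carbon, two bonds along the chain from two aromatic carbons and an oxygen on a saturated carbon. It shows that this position accepts the exchange of a six-membered aromatic ring of 7 heavy atoms for a ringless group of 2 heavy atoms without a difference beyond the scatter, so the 4-fluorophenyl ring is not needed here to hold the level of compound 1 while the tertiary alcohol and the rest of the shared core stay in place. No supporting measurement bears on this result, and the step alone gives no account of its origin.

The compounds shown leave open how an amine, a carboxylic acid or a longer saturated chain would read at this position, where only 4-fluorobenzyl and allyl stand so far. They also leave open what the tertiary alcohol contributes, as compound 1 and compound 4 both retain it and a methyl ether at that oxygen is not among them.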